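Replacing isobutylamino with diisopropylamino in an antiproliferative series

A few compounds are considered here, and "the series" means these few. Any claim that something is new, unique, unknown or untested is made for them only; others in the source may bear on it.

Compound 1 `CC(C)=CCc1cc(C(=O)Nc2cc3ccc(OCCC4CCCCN4)c(C)c3oc2=O)ccc1O`: 640 nM
Compound 2 `CCCN(CCC)CCCOc1ccc2cc(NC(=O)c3ccc(O)c(CC=C(C)C)c3)c(=O)oc2c1C`: > 50000 nM (a limit of the assay)
Compound 3 `CC(C)=CCc1cc(C(=O)Nc2cc3ccc(OCCCNCC(C)C)c(C)c3oc2=O)ccc1O`: 1030 nM

In a functional assay on SK-BR-3 cells (Homo sapiens) for antiproliferative activity (a lower number here means a stronger inhibitor, a higher number a weaker inhibitor), compound 3 gives 1030 nM, and the step of a 1.6-fold higher number from compound 1 to compound 3 (0.21 log units; within the scatter) stays within the scatter. Compound 4 `CC(C)=CCc1cc(C(=O)Nc2cc3ccc(OCCCN(C(C)C)C(C)C)c(C)c3oc2=O)ccc1O` differs from it by diisopropylamino in place of isobutylamino on a saturated chain carbon, three bonds along the chain from an oxygen on an aromatic ring. For the measured compounds named here, the closest precedent is the large step of an at least 48-fold lower number from compound 2 to compound 3 (1.68 log units; beyond the scatter), which exchanges dipropylamino for isobutylamino. The large step of an at least 78-fold higher number from compound 1 to compound 2 (1.89 log units; beyond the scatter) points the same way. Both rest on the limit of compound 2 alone, so their sizes are only bounds. A higher number, beyond the scatter, is therefore expected, though probably a smaller rise. The estimated step is a 6.8-fold higher number from compound 3 to compound 4 (0.83 log units; beyond the scatter). For compound 4 the expected value is 7000 nM, with an estimated range of 1200 nM to 50000 nM.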

Compound 4, half-maximal inhibitory concentration: 1600 nM
Estimate against measurement, compound 4: 4.4-fold (0.64 log units) above; measured number inside the range.
By their numbers in this assay, from the lowest: compounds 1, 3 and 4 (each within the scatter of the next, the first and the last beyond it). At a limit, above all of these: compound 2.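

In this assay, diisopropylamino, with 0 hydrogen-bond donors, serves at this place on the chain much as isobutylamino does: a 1.6-fold higher number from compound 3 to compound 4 (0.19 log units; within the scatter). Losing the donor therefore does not by itself explain compound 2, whose value is a limit of the assay, so that an at least 31-fold lower number from compound 2 to compound 4 (1.49 log units; beyond the scatter) is only a bound. Against the piperidin-2-yl group of compound 1 the change costs little, with a 2.5-fold higher number from compound 1 to compound 4 (0.40 log units; beyond the scatter).

From the compounds shown here alone, whether diethylamino, pyrrolidine or morpholine at the end of the same chain would hold this activity stays open. The compounds shown also do not tell why dipropylamino stands apart.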